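Swapping bromo for methoxy on compound 1

A few compounds are considered here, and "the series" means these few. Any claim that something is new, unique, unknown or untested is made for them only; others in the source may bear on it.

Within the data shown here, in a functional assay on ECa-109 cells for inhibition, with ECa-109 cell line (Homo sapiens) as the target, read by sulforhodamine B assay (a lower number here means a stronger inhibitor, a higher number a weaker inhibitor), compound 1 `O=C1C(Nc2ccc(Br)cc2)=CC(=O)c2c1nc1n2[C@H]2OC[C@@H](O)[C@H]2OC1` gives 1980 nM, the only actual number so far. Compound 2 `O=C1C=C(NC2CCCC2)C(=O)c2c1nc1n2[C@H]2OC[C@@H](O)[C@H]2OC1` reads > 16000 nM, which is a limit of the assay. Compound 3 `COc1ccc(NC2=CC(=O)c3c(nc4n3[C@H]3OC[C@@H](O)[C@H]3OC4)C2=O)cc1` keeps the rest of compound 1 but has methoxy in place of bromo on an aromatic carbon, turning 4-bromophenyl into 4-methoxyphenyl. Among the measured compounds shown here, no measured pair tests this swap in this assay, so the expected change stays within the scatter, leaning towards weaker inhibition. The estimated change is a step of a 1.5-fold higher number from compound 1 to compound 3 (0.18 log units; within the scatter). The estimate for compound 3 is 3000 nM, with an expected range from 1000 nM to 10000 nM.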

Compound 3, half-maximal inhibitory concentration: 3410 nM
Estimate against measurement, compound 3: 1.1-fold (0.06 log units) below, within the range that was stated.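

In this assay, methoxy in place of bromo gives a 1.7-fold higher number from compound 1 to compound 3 (0.24 log units; within the scatter) and so leaves the reading within the scatter. Among these compounds, this is the only measured pair that changes just this group, and it shows that on this aromatic carbon, para to a large group, the two groups cannot be told apart. No measurement shown says why they read alike.

From the compounds shown here alone, whether an amine or a carboxylic acid on the same carbon would shift the reading beyond the scatter remains open. So does the effect of a longer chain, such as butoxy, there.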